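One chlorine removed from the core of compound 2

The source may hold more compounds than are shown below. What is called first, only, known or untested is meant among the compounds shown, and "the series" means these compounds.

Three measured compounds share the core of compound 1 `ClCc1cccc(Cn2cnc3nc(Cl)nc(Cl)c32)c1` and differ in where the chloromethyl sits on the benzyl ring. In a functional assay on HOP-62 cells (Homo sapiens) for cytotoxicity, read by sulforhodamine B assay, with a stated time of 48 h (a lower number here means that less compound is tolerated, a higher number that more compound is tolerated), compound 1 gives 6020 nM. Compound 2 `ClCc1ccccc1Cn1cnc2nc(Cl)nc(Cl)c21` gives 16600 nM, the second highest of the three numbers; compound 3 `ClCc1ccc(Cn2cnc3c(Cl)nc(Cl)nc32)cc1` gives 19500 nM, within the scatter of compound 2, while compound 1 lies beyond it at a lower number. Compound 4 `ClCc1ccccc1Cn1cnc2ncnc(Cl)c21` keeps the benzyl of compound 2 and differs only by hydrogen in place of chloro on an aromatic carbon. Among the measured compounds shown here, no measured pair shows this change, so the step from compound 2 to compound 4 is expected to be small, toward a higher number or none beyond the scatter, a 1.5-fold higher number from compound 2 to compound 4 (0.18 log units; within the scatter). Compound 4 is estimated at 25000 nM, in the range 8000 nM to 80000 nM.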

Compound 4, concentration lethal to 50% of the cells: 75900 nM
Compound 4: middle estimate off by 3.0-fold (0.48 log units), on the low side, within the range that was stated.
By their numbers in this assay, from the lowest: compound 1; then compounds 2 and 3 (each within the scatter of the next); then compound 4.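

In this assay, the chloro group on the aromatic carbon between two ring nitrogen atoms is not a silent feature: hydrogen in its place gives a 4.6-fold higher number from compound 2 to compound 4 (0.66 log units; beyond the scatter), the first single-place change readable in the series. More compound is tolerated without this chloro group, on the benzyl pattern of compound 2. Nothing available explains the step. Open, from the compounds shown here alone, is whether an amine, a methoxy group or fluoro at this position would give a number nearer compound 2 or compound 4. Also open, going by these compounds, is whether the same change carries over to the benzyl patterns of compound 1 and compound 3.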